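This account rests on a few compounds, and the source may have more. Where it says the series, first, only, none or still open, it means among the compounds named here.

Measured so far:
compound 1, `N#Cc1cnc(NCc2cnccc2C(F)(F)F)cc1N[C@H]1CC[C@@H](O)CC1`: 100 nM
compound 2, `CNC(=O)[C@H]1CC[C@@H](Nc2cc(NCc3cnccc3C(F)(F)F)ncc2C#N)CC1`: 27 nM
compound 3, `CC1(C)[C@H](Nc2cc(NCc3cnccc3C(F)(F)F)ncc2C#N)C[C@H]1C(N)=O`: 140 nM

All three were tested in an assay on isolated protein for inhibition of protein kinase C theta type (Homo sapiens), read by TR-FRET, with a stated time of 2 h; on this read-out higher numbers stand for weaker inhibition and lower numbers for stronger inhibition. Compound 3 stands highest of the three numbers: a 1.4-fold higher number from compound 1 to compound 3 (0.15 log units; within the scatter), which is within the scatter, and a 5.2-fold higher number from compound 2 to compound 3 (0.71 log units; beyond the scatter), which is beyond it.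

Compound 4, `CC1(C)[C@@H](Nc2cc(NCc3cnccc3C(F)(F)F)ncc2C#N)C[C@H]1C(N)=O`, has the same atoms and bonds as compound 3 and differs only in configuration: the two compounds have the same atoms and bonds and differ only in configuration as drawn: 1 of 2 stereo elements differ; a stereocentre at a saturated ring carbon is drawn R in compound 3 and S in compound 4. Within the data shown here, none of the measured steps concerns a change of configuration; a 3.7-fold lower number from compound 1 to compound 2 (0.57 log units; beyond the scatter) and a 5.2-fold higher number from compound 2 to compound 3 (0.71 log units; beyond the scatter) each come from exchanging one group for another, and a 1.4-fold higher number from compound 1 to compound 3 (0.15 log units; within the scatter) does too. There is thus no measured guide to the size or direction of the step in this assay. Inverting one stereocentre in a ring can leave the number where it is or move it a modest amount either way, so a wide range is warranted. Compound 4 is therefore estimated at 140 nM, with a range from 40 nM to 500 nM. That estimate means no change at the digits printed from compound 3 to compound 4 (within the scatter), no change beyond the scatter expected.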

Compound 4, half-maximal inhibitory concentration: 140 nM
Estimate against measurement, compound 4: no gap at the digits printed; measured number inside the range.
By their numbers in this assay, from the lowest: compound 2; then compounds 1, 3 and 4 (each within the scatter of the next).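

In this assay, inverting a stereocentre at a saturated ring carbon gives no change at the digits printed from compound 3 to compound 4 (within the scatter), so at this position, and within this pair, the configuration as drawn leaves the number unmoved. This is the only change of configuration among these compounds, and nothing else varies in it: the fact that compounds 3 and 4 differ only in the configuration as drawn

The comparisons with the other compounds also read the same for either drawn form of the 3-carbamoyl-2,2-dimethylcyclobutyl group: there is a 5.2-fold higher number from compound 2 to compound 4 (0.71 log units; beyond the scatter), and a 1.4-fold higher number from compound 1 to compound 4 (0.15 log units; within the scatter).

The compounds shown leave open whether inverting the other stereocentre would also leave the number in place, and whether the same would hold with a carboxylic acid in place of the carbamoyl group. They also do not show how the 4-(methylcarbamoyl)cyclohexyl group of compound 2 would respond to a change of configuration.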